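The source may report more compounds than this note shows. Statements on the series, on what has been measured and on what is new or still open speak of the compounds shown alone.

Among the measured compounds shown here, compound 1 `O=C(NCCCCc1cccs1)n1c(=O)oc2ccccc21` is the only compound here with a number: in an assay on HEK293 cells for inhibition of acid ceramidase (Homo sapiens), with a stated time of 10 min (a lower number here means a stronger inhibitor, a higher number a weaker inhibitor), compound 1 gives 37 nM. Compound 2 `Cc1cccc2oc(=O)n(C(=O)NCCCCc3ccccc3)c12` gives no result reported in this assay. Compound 3 `O=C(NCCCCCCc1ccccc1)n1c(=O)oc2ccccc21` differs from compound 1 in a single place, (phenethyl in place of thiophen-2-yl on a saturated chain carbon, four bonds along the chain from an amide-type nitrogen). For the measured compounds named here, no measured pair shows a step of this kind. The step is nonetheless expected to be small, leaning if anything toward stronger inhibition and staying within the usual scatter, as a 1.5-fold lower number from compound 1 to compound 3 (0.17 log units; within the scatter). Compound 3 is accordingly estimated at 25 nM in this assay, with a likely range from 8 nM to 80 nM.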

Compound 3, half-maximal inhibitory concentration: 51 nM
Beside the measured number, compound 3's estimate is 2.0-fold (0.31 log units) below it; low and high end bracket the measured number.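

Phenethyl in place of thiophen-2-yl gives a 1.4-fold higher number from compound 1 to compound 3 (0.14 log units; within the scatter) in this assay, the first measured comparison at this position. The five-membered aromatic ring with its hetero atom can thus give way to phenethyl, with its six-membered aromatic ring of carbon only, without the number leaving the scatter. Nothing measured here offers an explanation for this result.

Because this change alters both the ring and the chain, the compounds shown do not separate those two contributions. On these data alone, how an amine or a carboxylic acid at this position would behave remains open.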